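The compounds below may be only part of what the source reports. "The series", "measured", "known", "first", "only" and "open" are said of these compounds alone.

Measured compounds:
compound 1 `Nc1ccccc1NC(=O)c1ccc(CSC(=S)N2CCN(Cc3ccncc3)CC2)cc1` — 18.4%
compound 2 `COc1ccc(N2CCN(C(=S)SCc3ccc(C(=O)Nc4ccccc4N)cc3)CC2)cc1` — 25.3%
compound 3 `Nc1ccccc1NC(=O)c1ccc(CSC(=S)N2CCN(c3ncccn3)CC2)cc1` — 28.4%

In a functional assay on MGC-803 cells (Homo sapiens) for antiproliferative activity, read by CCK-8 assay, with a stated time of 72 h, tested at 2 uM (a lower number here means a weaker effect, a higher number a stronger effect of the compound at the concentration tested), compound 3 gives 28.4%, the highest of the three numbers shown, although its gaps to both others fall inside the usual scatter: a number 3.1 percentage points higher from compound 2 to compound 3 (within the scatter) and a number 10 percentage points higher from compound 1 to compound 3 (within the scatter). Compound 4 `Nc1ccccc1NC(=O)c1ccc(CSC(=S)N2CCN(c3ccccc3)CC2)cc1` differs from compound 3 in a single place: phenyl in place of pyrimidin-2-yl on an amine nitrogen in a ring.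

Among the measured compounds shown here, the steps that bear on this change are the three already seen at the same ring nitrogen, where one group was exchanged for another: a number 6.9 percentage points higher from compound 1 to compound 2 (within the scatter), a number 10 percentage points higher from compound 1 to compound 3 (within the scatter) and a number 3.1 percentage points higher from compound 2 to compound 3 (within the scatter). Every one of them stays inside the scatter, so the exchange of groups at this position has so far left the read-out essentially unmoved. On that basis the step is expected to be small as well, a number 3.4 percentage points lower from compound 3 to compound 4 (within the scatter), with no direction that can be told apart from noise. Compound 4 is therefore estimated to give 25%, with a range from 12% to 38%.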

Compound 4, a percentage reported as inhibition, at one concentration (the size of the read-out at that concentration, not a potency): 42.3%
The estimate for compound 4 lay 17.3 percentage points below the measured number; the measured number lies above the stated range.
By their numbers in this assay, from the lowest: compounds 1, 2 and 3 (each within the scatter of the next); then compound 4.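

Among the compounds shown here, compound 4 is the first compound in this assay to separate from the others, since exchanges at this ring nitrogen had so far stayed inside the scatter. Phenyl on the amine nitrogen stands apart from both pyrimidin-2-yl (a number 13.9 percentage points higher from compound 3 to compound 4 (beyond the scatter)) and (pyridin-4-yl)methyl (a number 23.9 percentage points higher from compound 1 to compound 4 (beyond the scatter)), and hydrogen in place of methoxy on the aromatic carbon also gives a step beyond the scatter (a number 17 percentage points higher from compound 2 to compound 4 (beyond the scatter)), so compound 4 is the most active of the four at the concentration tested, though all three steps are modest. No measurement shown here accounts for these steps.

It remains open whether other groups on the phenyl ring, such as fluoro, chloro, hydroxyl or an amine, would keep this read-out or lose it, since methoxy is the only such group shown. A benzyl group on the same ring nitrogen would show whether the phenyl result holds with a carbon link between the ring nitrogen and the aromatic ring.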